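The source may report more compounds than this note shows. Statements on the series, on what has been measured and on what is new or still open speak of the compounds shown alone.

Compound 1 `CCC(c1ccc(O)c(OC)c1)c1cccc(O)c1O` gives 34% in a functional assay for inhibition, with a stated time of 6 h, tested at 100 ug/mL; a higher number here means more inhibition at the concentration tested (going by the name of the read-out), a lower number less inhibition.
Compound 2 `CCOc1cccc(C(CC)c2ccc(O)c(OC)c2)c1O` gives 37% in this assay.
Compound 3 `CCC(c1ccc(O)c(OC)c1)c1ccccc1O` gives 32% in this assay.

Compound 3 has the lowest of the three numbers, yet the gaps to its neighbours are within the scatter: a number 2 percentage points lower from compound 1 to compound 3 (within the scatter) and a number 5 percentage points lower from compound 2 to compound 3 (within the scatter). The three compounds are therefore, on these numbers, indistinguishable.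

Compound 4 `CCC(c1ccc(O)c(OC)c1)c1cccc(C(C)C)c1O` is the next compound. Its change from compound 3 is isopropyl in place of hydrogen on an aromatic carbon.

Among the compounds with values here, no measured step adds an isopropyl anywhere, so none bears on this change directly. The three steps that exist all alter groups on the same ring or its oxygen and are all small: a number 3 percentage points higher from compound 1 to compound 2 (within the scatter), a number 2 percentage points lower from compound 1 to compound 3 (within the scatter), a number 5 percentage points lower from compound 2 to compound 3 (within the scatter). Every change tried so far has left this assay within the scatter, and an isopropyl in place of hydrogen is expected to do the same, so the expected step is a number 3 percentage points higher from compound 3 to compound 4 (within the scatter). Compound 4 is estimated at 35% in this assay, with a range from 20% to 50%.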

Compound 4, a percentage reported as inhibition, at one concentration (the size of the read-out at that concentration, not a potency): 38%
Compound 4: the middle estimate sits 3 percentage points below what was measured, and the stated range covers the measured number.
By their numbers in this assay, from the lowest: compounds 3, 1, 2 and 4 (each within the scatter of the next).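

At the position ortho to a hydroxy group, an isopropyl, which carries no hydrogen-bond donors or acceptors, still leaves this assay unmoved beyond the scatter: adding it in place of hydrogen gives a number 6 percentage points higher from compound 3 to compound 4 (within the scatter). Replacing hydroxy with isopropyl gives a number 4 percentage points higher from compound 1 to compound 4 (within the scatter), and replacing ethoxy with isopropyl gives a number 1 percentage points higher from compound 2 to compound 4 (within the scatter), so hydrogen, hydroxy, ethoxy and isopropyl cannot be told apart here. Nothing available explains why these four groups read alike.

As far as these compounds go, whether an amine, a carboxylic acid or a longer chain at this position would produce a step beyond the scatter remains open. Each number also comes from a single concentration, so any difference in potency among these compounds stays unknown.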